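Cyclopentyl for Isopropyl: Expecting a Small Step

The source may report more compounds than this note shows. Statements on the series, on what has been measured and on what is new or still open speak of the compounds shown alone.

Measured so far in a functional assay on NCI-H460 cells (Homo sapiens) for antiproliferative activity, read by CCK-8 assay, with a stated time of 72 h, tested at 8 uM; a lower number here means a weaker effect, a higher number a stronger effect of the compound at the concentration tested:
compound 1, `CC(C)n1cnc2c(Nc3ccccc3)nc(NCOCc3ccc(C(=O)Nc4ccccc4N)cc3)nc21`, gives 34.3%;
compound 2, `CCC(C)n1cnc2c(NCc3ccc(C(=O)Nc4ccccc4N)cc3)nc(Cl)nc21`, gives 67.7%;
compound 3, `CC(C)n1cnc2c(Nc3ccccc3)nc(NCOCc3ccc(/C=C/C(=O)Nc4ccccc4N)cc3)nc21`, gives 53.1%.

Compound 3 stands second highest of the three numbers. Compound 2 lies above it and compound 1 below it, both gaps beyond the scatter, as the values show. For the measured compounds named here, the only step measured so far between compounds that differ in one place is a number 18.8 percentage points higher from compound 1 to compound 3 (beyond the scatter), a modest gain when 2-((2-aminophenyl)carbamoyl)ethenyl replaces (2-aminophenyl)carbamoyl on an aromatic carbon.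

Compound 4, `Nc1ccccc1NC(=O)/C=C/c1ccc(COCNc2nc(Nc3ccccc3)c3ncn(C4CCCC4)c3n2)cc1`, differs from compound 3 as follows: cyclopentyl in place of isopropyl on an aromatic nitrogen. Going by the values given here, this change sits at the aromatic nitrogen of the shared core, a place that no measured step touches. The step from compound 1 to compound 3 concerns a different part of the molecule and therefore gives no direct guidance here. With nothing measured that bears on it, the safest expectation in this assay is a step of no more than the scatter in either direction.

Compound 4 is therefore estimated at 55%, with a range from 40% to 70%. The step this estimate means, a number 1.9 percentage points higher from compound 3 to compound 4 (within the scatter), is expected to stay within the scatter.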

Compound 4, a percentage reported as inhibition, at one concentration (the size of the read-out at that concentration, not a potency): 59.7%
Beside the measured number, compound 4's estimate is 4.7 percentage points below it, and the stated range covers the measured number.
By their numbers in this assay, from the lowest: compound 1; then compounds 3, 4 and 2 (each within the scatter of the next, the first and the last beyond it).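

In this assay, for the compounds shown here, a measured step reaches the aromatic nitrogen of the shared core for the first time, and with cyclopentyl in place of isopropyl the step is a number 6.6 percentage points higher from compound 3 to compound 4 (within the scatter) at the one concentration tested. This position therefore accepts a group of 5 heavy atoms with a five-membered non-aromatic ring in place of one of 3 heavy atoms with no ring, and the read-out of the two compounds stays within the scatter. Nothing available explains this result or tells what either group does at this nitrogen.

Going by these compounds, both groups compared here contain carbon only, so it remains open whether a group carrying an amine or a carboxylic acid, or a longer open chain such as n-hexyl, would give a similar number on this nitrogen. On these data alone, it is also open whether cyclopentyl would give the same result on compound 1, which carries the (2-aminophenyl)carbamoyl group rather than the 2-((2-aminophenyl)carbamoyl)ethenyl group.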